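Aryl swap on the ring nitrogen of the shared core

The compounds below may be only part of what the source reports. "The series", "measured", "known", "first", "only" and "open" are said of these compounds alone.

Compound 3 `CC(C)n1ncc2c(C(=O)NCc3cn(-c4cccc(Br)c4)nn3)cccc21` is the point of departure. In a functional assay on MCF7 cells (Homo sapiens) for inhibition, read by MTT assay, with a stated time of 72 h (on this read-out higher numbers stand for weaker inhibition and lower numbers for stronger inhibition), compound 3 reaches only the limit of the assay, > 40000 nM, so no number stands for it. Compound 1 `Cc1ccc(-n2cc(CNC(=O)c3cccc4c3cnn4C(C)C)nn2)c(C)c1` carries a 2,4-dimethylphenyl on the same aromatic nitrogen. In this assay compound 1 also sits at the limit, > 40000 nM. Compound 2 `CC(C)n1ncc2c(C(=O)NCc3cn(-c4ccc(F)cc4)nn3)cccc21` carries a 4-fluorophenyl. In this assay compound 2 likewise gives only the limit, > 40000 nM. The whole set is summed up by the limit of > 40000 nM in this assay, at which 3 of the 3 values shown sit. The three aryl exchanges give a step that the two limits leave unreadable from compound 1 to compound 2, a step that the two limits leave unreadable from compound 1 to compound 3 and a step that the two limits leave unreadable from compound 2 to compound 3, so the size of any effect of the aryl group is not readable from them.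

Compound 4 `CC(C)n1ncc2c(C(=O)NCc3cn(-c4ccc([N+](=O)[O-])cc4)nn3)cccc21` differs from compound 3 by 4-nitrophenyl in place of 3-bromophenyl on an aromatic nitrogen. Among the measured compounds shown here, nothing among the measured steps is readable, so the expected step that the limit leaves unreadable from compound 3 to compound 4 from compound 3 to compound 4 in this assay has no direction that the data support. Compound 4 is therefore estimated to fall at 60000 nM, with a range from 20000 nM to 200000 nM, most likely again reported only as a limit.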

Compound 4, half-maximal inhibitory concentration: > 40000 nM
Compound 4 gave a limit, no number; the forecaster's own chance of this, stated with the estimate: 80%; the middle value lies beyond the limit too.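

In this assay compound 4 gives only a limit, > 40000 nM. Its steps from compound 1, compound 2 and compound 3 therefore cannot be read: the limit of > 40000 nM in this assay, at which 4 of the 4 values shown sit.

The compounds shown leave open whether any aryl group on this aromatic nitrogen changes inhibition at all, and by how much.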